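Lengthening the Azido Chain from Compound 2 to Compound 3

The compounds below may be only part of what the source reports. "The series", "measured", "known", "first", "only" and "open" are said of these compounds alone.

Compound 1 `CCNC(=O)Nc1ccc(-c2nc3n(Cc4c(F)cccc4F)cc(C(=O)OCC)c(=O)n3c2CN(CC(=O)NCc2cn(CCOCCOCCN=[N+]=[N-])nn2)Cc2ccccc2)cc1` gives 468 nM in a functional assay on CHO cells for antagonist activity at Gonadotropin-releasing hormone receptor (Homo sapiens), read by a luciferase reporter, with a stated time of 30 min; a higher number here means a weaker inhibitor, a lower number a stronger inhibitor. Compound 2 `CCNC(=O)Nc1ccc(-c2nc3n(Cc4c(F)cccc4F)cc(C(=O)NCc4cn(CCOCCN=[N+]=[N-])nn4)c(=O)n3c2CN(C)Cc2ccccc2)cc1` is known in this assay only as a limit, < 10000 nM, and the fact that the limit of < 10000 nM in this assay, at which 1 of the 2 values shown sits, leaves its true value open. Compound 3 `CCNC(=O)Nc1ccc(-c2nc3n(Cc4c(F)cccc4F)cc(C(=O)NCc4cn(CCOCCOCCOCCN=[N+]=[N-])nn4)c(=O)n3c2CN(C)Cc2ccccc2)cc1` has not yet been measured; it differs from compound 2 by 2-(2-azidoethoxy)ethoxy in place of azido on a saturated chain carbon, two bonds along the chain from an oxygen on a saturated carbon. Since compound 2 offers no number, no step can be read from the pair, and the change is expected to move potency no further than the scatter. Compound 3 is expected to reach about 1500 nM, within 300 nM to 8000 nM. The step that this estimate implies is expected to be a step that the limit leaves unreadable from compound 2 to compound 3.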

Compound 3, half-maximal inhibitory concentration: < 10000 nM
Compound 3: no number, only a limit; the forecaster's own chance of this, stated with the estimate: 30%; the middle value does not contradict the limit.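

Compound 3, like compound 2, is known in this assay only as a limit, so no step can be read between them: the limit of < 10000 nM in this assay, at which 2 of the 3 values shown sit.

The compounds shown leave open how 2-(2-azidoethoxy)ethoxy in place of azido moves potency, and where the true values of compound 2 and compound 3 lie.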